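The source may hold more compounds than are shown below. What is called first, only, known or untested is meant among the compounds shown, and "the series" means these compounds.

Values in a physicochemical assay for solubility, at pH 7.4; on this read-out lower numbers stand for lower solubility and higher numbers for higher solubility:
compound 1 `O=C(NCC1CCOCC1)c1cnc(Nc2cccc(Br)c2)cc1C1CC1`: 45 ug/mL
compound 2 `O=C(NCC1CCOCC1)c1cnc(Nc2cccc(OC(F)(F)F)c2)cc1C1CC1`: < 1 ug/mL, a limit of the assay
compound 3 `O=C(NCC1CCOCC1)c1cnc(Nc2ccc(Cl)c(Cl)c2)cc1C1CC1`: 6 ug/mL

Compound 3 holds the lower of the two actual numbers, and compound 2 gives only a limit. Next is compound 4 `N#Cc1cccc(Nc2cc(C3CC3)c(C(=O)NCC3CCOCC3)cn2)c1`, with this change: 3-cyanophenyl in place of 3,4-dichlorophenyl on a nitrogen on an aromatic ring. Two measured steps alter the same group, both downward: the modest 7.5-fold lower number from compound 1 to compound 3 (0.88 log units; beyond the scatter) and the large at least 45-fold lower number from compound 1 to compound 2 (1.65 log units; beyond the scatter). Neither introduces a nitrile, so both guide only loosely. Compound 1, at 45 ug/mL, is taken as the closest reference for 3-cyanophenyl. A modest rise in this assay is therefore expected, a 4.2-fold higher number from compound 3 to compound 4 (0.62 log units; beyond the scatter). For compound 4 the estimate is 25 ug/mL, with an expected range of 6 ug/mL to 100 ug/mL.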

Compound 4, solubility: 4 ug/mL
The estimate for compound 4 lay 6.3-fold (0.80 log units) above the measured number; measured number below the stated range.
By their numbers in this assay, from the lowest: compounds 4 and 3 (each within the scatter of the next); then compound 1. At a limit, below all of these: compound 2.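

In this assay, 3-cyanophenyl does not keep the standing of the bromo compound: an 11-fold lower number from compound 1 to compound 4 (1.05 log units; beyond the scatter). Against 3,4-dichlorophenyl it is not separated, a 1.5-fold lower number from compound 3 to compound 4 (0.18 log units; within the scatter), so among the groups shown on this nitrogen, only 3-bromophenyl stands clear of all the others. The remaining step is bounded on one side, since the value for compound 2 is a limit, an at least 4.0-fold higher number from compound 2 to compound 4 (0.60 log units; beyond the scatter): the limit of < 1 ug/mL in this assay, at which 1 of the 4 values shown sits.

Still open, going by these compounds, is whether an amine or a carboxylic acid on this phenyl ring would go beyond compound 1. Also open is why bromo stands apart from cyano, which these values do not explain.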